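A few compounds are considered here, and "the series" means these few. Any claim that something is new, unique, unknown or untested is made for them only; others in the source may bear on it.

Of the compounds shown here, three have been measured in a physicochemical assay for solubility, measured as kinetic solubility; on this read-out lower numbers stand for lower solubility and higher numbers for higher solubility. Compound 1, with the structure `CC(=O)Nc1cc(-c2ccc(N(C)C(=O)c3c(F)cccc3Cl)c(N3CCCCC3)c2)n(C(C)C)n1`, gives 1.3 ug/mL. Compound 2, with the structure `CC(=O)Nc1cc(-c2ccc(N(C)C(=O)c3c(F)cccc3Cl)c(N3CC4CC4C3)c2)n(C2CCC2)n1`, gives 0.5 ug/mL, and compound 3, with the structure `CC(C)n1nc(C(N)=O)cc1-c1ccc(N(C)C(=O)c2c(F)cccc2Cl)c(OCC(F)(F)F)c1`, gives 32 ug/mL. Among these three numbers compound 1 stands second highest: the number for compound 2 is lower than that of compound 1 by a gap beyond the usual scatter, and the number for compound 3 is higher than that of compound 1 by a gap that is also beyond the scatter, and by a wider margin.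

Compound 4, with the structure `CC(=O)Nc1cc(-c2ccc(N(C)C(=O)c3c(F)cccc3Cl)c(N3CCCC3)c2)n(C(C)C)n1`, has not yet been measured. It differs from compound 1 in one place: pyrrolidin-1-yl in place of piperidin-1-yl on an aromatic carbon. Among the compounds with values here, no pair of measured compounds shows this kind of change on its own, so there is no measured step to lean on. The change is small in what is counted, and the expected step in this assay a 1.5-fold higher number from compound 1 to compound 4 (0.19 log units; within the scatter) is a slight rise that may well stay within the scatter. Compound 4 is therefore estimated at 2 ug/mL, with a range from 0.7 ug/mL to 6 ug/mL.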

Compound 4, solubility: 12 ug/mL
Compound 4: middle estimate off by 6.0-fold (0.78 log units), on the low side; measured number outside the range, above it.
By their numbers in this assay, from the lowest: compound 2; then compound 1; then compound 4; then compound 3.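

In this assay, putting pyrrolidin-1-yl in place of piperidin-1-yl on this aromatic carbon, ortho to the ((2-chloro-6-fluorophenyl)carbonyl)(methyl)amino group, gives a 9.2-fold higher number from compound 1 to compound 4 (0.97 log units; beyond the scatter), a step beyond the usual scatter. Within the data shown here, this is the first pair of compounds that differ in one place, so it is the first sign that the number can move at this position while the rest of the molecule stays fixed, even though a six-membered non-aromatic ring only gives way to a five-membered one, with hydrogen-bond donors, hydrogen-bond acceptors and net charge counted the same on both sides. No measurement at hand gives a reason for this step.

A single pair cannot show whether the number follows ring size at this position, and an azetidin-1-yl, a morpholin-4-yl or an open-chain dimethylamino group in the same place would be needed to test that. As far as these compounds go, whether the same swap gives a step of similar size when other groups sit elsewhere on the core also remains open.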